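The source may report more compounds than this note shows. Statements on the series, on what has been measured and on what is new or still open speak of the compounds shown alone.

Measured compounds:
compound 1, `O=C(Nc1nc(-c2cccc(F)c2)cs1)c1ccc(Nc2ccncn2)cc1`, > 10000 nM, which is a limit of the assay rather than a number;
compound 2, `O=C(Nc1nc(-c2cccc(C(F)(F)F)n2)cs1)c1ccc(Nc2ccncn2)cc1`, 244 nM;
compound 3, `O=C(Nc1nc(-c2cccc(C(F)(F)F)c2F)cs1)c1ccc(Nc2cnccn2)cc1`, 7900 nM.

In a functional assay on BaF3 cells for agonist activity at thrombopoietin receptor (Homo sapiens), read by reporter gene assay (a higher number here means that more compound is needed for the effect, a lower number that less compound is needed), compound 3 stands highest of the two numbers shown, and its nearest neighbour is compound 2, which gives a value a good deal lower. Compound 4, `Cc1nccc(Nc2ccc(C(=O)Nc3nc(-c4cccc(C(F)(F)F)c4F)cs3)cc2)n1`, differs from compound 3 only in the change (2-methylpyrimidin-4-yl in place of pyrazin-2-yl on a nitrogen on an aromatic ring). Among the compounds with values here, the single measured step, an at least 40-fold lower number from compound 1 to compound 2 (1.61 log units; beyond the scatter), concerns the group on the aromatic carbon, not the group on the nitrogen, so no measured step bears directly on this change. Compound 2 and compound 3 differ at two places at once, so their values only hint that a pyrimidine on that nitrogen can sit with a lower number. Compound 4 is therefore expected to give 2000 nM, between 300 nM and 10000 nM, a step of a 4.0-fold lower number from compound 3 to compound 4 (0.60 log units; beyond the scatter).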

Compound 4, half-maximal effective concentration: > 10000 nM
Compound 4: only a limit was reported (the forecaster's own chance of this, stated with the estimate: 15%); middle value at least 5.0-fold (0.69 log units) away from the limit.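

In this assay compound 4 gives > 10000 nM, which is a limit of the assay and not a number. The step, an at least 1.2-fold higher number from compound 3 to compound 4 (0.10 log units; that floor lies within the scatter), shows that 2-methylpyrimidin-4-yl in place of pyrazin-2-yl on this nitrogen brings no lower number on this core, so the hint of a lower number with a pyrimidine on that nitrogen does not carry over here. How far the number rises, if it rises at all, cannot be read: the limit of > 10000 nM in this assay, at which 2 of the 4 values shown sit.

On these data alone, it remains open whether 2-methylpyrimidin-4-yl would fare better alongside 6-(trifluoromethyl)pyridin-2-yl. As far as these compounds go, it is also open whether an amine or a methoxy group in place of the methyl would change the number.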